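Tetrazole for Carboxylic Acid on a Quinolinylmethoxy Aryl Core

The compounds below may be only part of what the source reports. "The series", "measured", "known", "first", "only" and "open" are said of these compounds alone.

Measured compounds:
- compound 1 `CC(CCc1cccc(OCc2ccc3ccccc3n2)c1)Cc1nnn[nH]1`: 17 nM
- compound 2 `CC(CCC(=O)O)Cc1cccc(OCc2ccc3ccccc3n2)c1`: 140 nM
- compound 3 `c1ccc2nc(COc3ccc(OCCCc4nnn[nH]4)cc3)ccc2c1`: 69 nM

In an assay on membranes from lung (Cavia porcellus) for binding affinity to cysteinyl leukotriene receptor (Homo sapiens) (a lower number here means a stronger inhibitor, a higher number a weaker inhibitor), compound 2 gives the highest of the three numbers; compound 3 sits nearest with 69 nM, and compound 1 is furthest with 17 nM. Compound 4 `c1cc(OCCCc2nnn[nH]2)cc(OCc2ccc3ccccc3n2)c1` has not been measured yet. It differs from compound 2 by 3-(1H-tetrazol-5-yl)propoxy in place of 4-carboxy-2-methylbutyl on an aromatic carbon. Among the compounds with values here, the one measured step that bears on the change is the exchange of a tetrazole-bearing chain for a carboxylic acid chain, which gave an 8.2-fold higher number from compound 1 to compound 2 (0.92 log units; beyond the scatter). Compound 3 also carries the 3-(1H-tetrazol-5-yl)propoxy group and gives 69 nM, a lower number than compound 2. Taken together, compound 4 is expected to show a lower number than compound 2 in this assay, an expected step of about a 4.7-fold lower number from compound 2 to compound 4 (0.67 log units; beyond the scatter). The estimate for compound 4 is therefore 30 nM, with a likely range from 10 nM to 90 nM.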

Compound 4, inhibition constant: 42 nM
Compound 4: the middle estimate sits 1.4-fold (0.15 log units) below what was measured; the measured number falls inside the stated range.
By their numbers in this assay, from the lowest: compound 1; then compounds 4 and 3 (each within the scatter of the next); then compound 2.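

In this assay, the exchange on an aromatic carbon gives a 3.3-fold lower number from compound 2 to compound 4 (0.52 log units; beyond the scatter), so the tetrazole compound again has the lower number, now with the 3-(1H-tetrazol-5-yl)propoxy chain rather than the all-carbon chain of the earlier pair. This step differs from an 8.2-fold higher number from compound 1 to compound 2 (0.92 log units; beyond the scatter) in more than the end group, since the 4-carboxy-2-methylbutyl group that leaves has a branching methyl and the group that enters has an ether oxygen, and the single step cannot divide its size among these features. The data shown offer no explanation for the step.

As far as these compounds go, it remains open how a carboxylic acid at the end of the same propoxy chain would compare with the tetrazole. From the compounds shown here alone, the effect of a longer chain at this position also remains open.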